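The compounds below may be only part of what the source reports. "The series", "measured", "known", "first", "only" and "open" are said of these compounds alone.

Measured in a functional assay on A-375 cells (Homo sapiens) for antiproliferative activity, read by CCK-8 assay, with a stated time of 72 h, tested at 8 uM; on this read-out higher numbers stand for a stronger effect at the one concentration tested and lower numbers for a weaker effect:
compound 1 `Nc1ccccc1NC(=O)c1ccc(CSC(=S)N2CCN(Cc3ccccc3)CC2)cc1` gives 29.3%
compound 2 `Nc1ccccc1NC(=O)c1ccc(CSC(=S)N2CCN(c3cnccn3)CC2)cc1` gives 85.8%
compound 3 `N#Cc1ccc(N2CCN(C(=S)SCc3ccc(C(=O)Nc4ccccc4N)cc3)CC2)cc1` gives 62.9%

Compound 3 stands second highest of the three numbers in this assay. The step of a number 22.9 percentage points lower from compound 2 to compound 3 (beyond the scatter) sets it beneath the top of the set, while the step of a number 33.6 percentage points higher from compound 1 to compound 3 (beyond the scatter) sets it well above the bottom.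

Compound 4 `Nc1ccccc1NC(=O)c1ccc(CSC(=S)N2CCN(c3ccccc3)CC2)cc1` differs from compound 3 by hydrogen in place of cyano on an aromatic carbon. Among the measured compounds shown here, no measured step removes a cyano on its own. For the measured compounds named here, the steps that bear on the site are those that exchange the whole group on the amine nitrogen in a ring: a number 33.6 percentage points higher from compound 1 to compound 3 (beyond the scatter) and a number 56.5 percentage points higher from compound 1 to compound 2 (beyond the scatter) were large, and a number 22.9 percentage points lower from compound 2 to compound 3 (beyond the scatter) was modest, all beyond the scatter. They show that the group on that nitrogen moves the read-out strongly, but they leave the weight of the cyano itself unknown. Compound 4 keeps an aryl on that nitrogen, as compound 2 and compound 3 do, so a loss in this assay of modest size, or none beyond the scatter, is expected. Compound 4 is expected to give 50%, within 25% to 78%. This estimate means an expected step of a number 12.9 percentage points lower from compound 3 to compound 4 (beyond the scatter).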

Compound 4, a percentage reported as inhibition, at one concentration (the size of the read-out at that concentration, not a potency): 88.6%
The estimate for compound 4 lay 38.6 percentage points below the measured number; measured number outside the range, above it.
By their numbers in this assay, from the lowest: compound 1; then compound 3; then compounds 2 and 4 (each within the scatter of the next).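

In this assay taking away the cyano alone gave a number 25.7 percentage points higher from compound 3 to compound 4 (beyond the scatter) and so separated the weight of this group, para to a large group, from the whole-group exchanges on the amine nitrogen in a ring: here 4-cyanophenyl stands lower than phenyl. With a number 2.8 percentage points higher from compound 2 to compound 4 (within the scatter) phenyl and pyrazin-2-yl cannot be told apart, whereas a number 59.3 percentage points higher from compound 1 to compound 4 (beyond the scatter) sets phenyl well above benzyl, and among these compounds all three groups with the ring joined directly to that nitrogen stand above benzyl, although compound 3 stays lower than compound 2 and compound 4. No measured evidence accounts for the effect of the cyano.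

The compounds shown leave open whether a methoxy, a chlorine or a carboxylic acid at this place would lower the read-out as the cyano does. They also leave open how a longer chain on that nitrogen would compare with benzyl.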